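Hydroxyphenyl to Chlorophenyl on a Shared Pyridone-Type Core

The source may report more compounds than this note shows. Statements on the series, on what has been measured and on what is new or still open speak of the compounds shown alone.

Compound 1, `N#Cc1c(-c2ccccc2)c(C#N)c(=O)n(/N=C/c2cn(-c3ccccc3)nc2-c2ccccc2)c1N`, carries an unsubstituted phenyl on the shared core. In an ADME assay on HeLa cells (Homo sapiens) for cytotoxicity, read by MTT assay (on this read-out higher numbers stand for weaker inhibition and lower numbers for stronger inhibition), compound 1 gives > 200 ug/mL, which is a limit of the assay and not a number. Compound 2, `N#Cc1c(-c2ccccc2O)c(C#N)c(=O)n(/N=C/c2cn(-c3ccccc3)nc2-c2ccccc2)c1N`, bears a 2-hydroxyphenyl instead. In this assay compound 2 gives > 200 ug/mL, again a limit. Compound 3, `N#Cc1c(-c2ccc(O)cc2)c(C#N)c(=O)n(/N=C/c2cn(-c3ccccc3)nc2-c2ccccc2)c1N`, bears a 4-hydroxyphenyl. In this assay compound 3 gives > 200 ug/mL, once more a limit. The steps a step that the two limits leave unreadable from compound 1 to compound 2, a step that the two limits leave unreadable from compound 1 to compound 3 and a step that the two limits leave unreadable from compound 2 to compound 3 therefore have no readable size, as all three values sit at the limit of > 200 ug/mL in this assay, at which 3 of the 3 values shown sit.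

Compound 4, `N#Cc1c(-c2ccccc2Cl)c(C#N)c(=O)n(/N=C/c2cn(-c3ccccc3)nc2-c2ccccc2)c1N`, differs from compound 3 by 2-chlorophenyl in place of 4-hydroxyphenyl on an aromatic carbon. Among the compounds with values here, no measured step bears readably on this change, so the step that the limit leaves unreadable from compound 3 to compound 4 is expected to be none beyond the scatter. In this assay compound 4 is expected to give about 250 ug/mL, with a range from 100 ug/mL to 600 ug/mL, most likely reported again only as a limit.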

Compound 4, half-maximal inhibitory concentration: > 200 ug/mL
Compound 4 gave a limit, no number; the forecaster's own chance of this, stated with the estimate: 80%; the middle value does not contradict the limit.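

No new step can be read between compound 4 and compound 1, compound 2 or compound 3 in this assay, since all four stand at one limit and not at a number: the limit of > 200 ug/mL in this assay, at which 4 of the 4 values shown sit.

The compounds shown leave open whether any group on this phenyl ring would give a readable number in this assay.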